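The source may report more compounds than this note shows. Statements on the series, on what has been measured and on what is new or still open speak of the compounds shown alone.

In a functional assay on HT-29 cells (Homo sapiens) for antiproliferative activity, read by MTT assay, with a stated time of 72 h (on this read-out higher numbers stand for weaker inhibition and lower numbers for stronger inhibition), compound 2 `Cn1ccc2c(Oc3ccc(NC(=O)c4cc5cccnc5n(-c5ccc(F)cc5)c4=O)cc3F)ccnc21` has the lower of the two numbers shown, giving 160 nM, while compound 1 `Cn1ccc2c(Oc3ccc(NC(=O)c4cc5cccnc5n(-c5ccccc5)c4=O)cc3F)ccnc21` gives 510 nM; the only measured step is a 3.2-fold lower number from compound 1 to compound 2 (0.50 log units; beyond the scatter). Compound 3 `Cn1ccc2c(Oc3ccc(NC(=O)c4cc5cccnc5n(-c5ccc(Br)cc5)c4=O)cc3F)ccnc21` differs from compound 2 by bromo in place of fluoro on an aromatic carbon. Going by the values given here, no measured step exchanges one halogen for another, so the size of the change cannot be read from the data; the single halogen step was modest, and a similar or smaller move is expected here, a 1.1-fold lower number from compound 2 to compound 3 (0.03 log units; within the scatter). Compound 3 is therefore estimated at 150 nM, within 60 nM to 400 nM.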

Compound 3, half-maximal inhibitory concentration: 330 nM
Beside the measured number, compound 3's estimate is 2.2-fold (0.34 log units) below it, and the stated range covers the measured number.
By their numbers in this assay, from the lowest: compound 2; then compounds 3 and 1 (each within the scatter of the next).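

In this assay, the identity of the halogen on this aromatic carbon matters: bromo in place of fluoro gives a 2.1-fold higher number from compound 2 to compound 3 (0.31 log units; beyond the scatter) and so gives back part of what fluoro gained over hydrogen. Bromo in place of hydrogen gives a 1.5-fold lower number from compound 1 to compound 3 (0.19 log units; within the scatter) and so cannot be told apart from no substituent at all. No measurement at hand bears on why fluoro and bromo differ here. Still open, from the compounds shown here alone, is how chloro, methyl or an amine would read at this same place, and whether the edge of the 4-fluorophenyl group holds on other cell types.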